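Acetyl for Methyl on a Sulfonamide Nitrogen

The source may hold more compounds than are shown below. What is called first, only, known or untested is meant among the compounds shown, and "the series" means these compounds.

Compound 1 `CCCS(=O)(=O)Nc1ccc(F)c(C(=O)c2n[nH]c3ncc(-c4ccccc4)cc23)c1F`: 2.4%
Compound 2 `CCCS(=O)(=O)Nc1ccc(F)c(C(=O)c2n[nH]c3ncc(-c4ccc(S(C)(=O)=O)cc4)cc23)c1F`: 1.5%
Compound 3 `CCCS(=O)(=O)Nc1ccc(F)c(C(=O)c2n[nH]c3ncc(-c4ccc(S(=O)(=O)NC)cc4)cc23)c1F`: 1.2%

Of the compounds shown here, three sharing one core have been measured in an assay for binding affinity to dual specificity mitogen-activated protein kinase kinase 4 (Homo sapiens), read by KINOMEscan, tested at 100 nM; a higher number here means a weaker effect of the compound at the concentration tested, a lower number a stronger effect. Compound 3 holds the lowest of the three numbers, but its neighbours sit close by: the step of a number 0.3 percentage points lower from compound 2 to compound 3 (within the scatter) and the step of a number 1.2 percentage points lower from compound 1 to compound 3 (within the scatter) are both within the scatter, as is the step of a number 0.9 percentage points lower from compound 1 to compound 2 (within the scatter). Nothing in these three numbers sets one compound apart from another.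

Compound 4 `CCCS(=O)(=O)Nc1ccc(F)c(C(=O)c2n[nH]c3ncc(-c4ccc(S(=O)(=O)NC(C)=O)cc4)cc23)c1F` has not yet been measured. It differs from compound 3 by acetyl in place of methyl on a sulfonamide nitrogen. Within the data shown here, the one measured step at the same place, a number 0.3 percentage points lower from compound 2 to compound 3 (within the scatter), stayed within the scatter, and the two steps that put a group in place of hydrogen on an aromatic carbon, a number 0.9 percentage points lower from compound 1 to compound 2 (within the scatter) and a number 1.2 percentage points lower from compound 1 to compound 3 (within the scatter), stayed within the scatter as well. Among the measured compounds shown here, the change to compound 4 is larger than the one already measured at this sulfonamide nitrogen, yet no measured step gives ground to expect a step beyond the scatter. Compound 4 is therefore expected to read 1.6%, with a range from 0.3% to 7%. The expected step of a number 0.4 percentage points higher from compound 3 to compound 4 (within the scatter) is estimated to remain within the scatter.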

Compound 4, a percentage reported as activity, at one concentration (the size of the read-out at that concentration, not a potency): 0.35%
Compound 4: the middle estimate sits 1.3 percentage points above what was measured, within the range that was stated.
By their numbers in this assay, from the lowest: compounds 4, 3, 2 and 1 (each within the scatter of the next).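

In this assay acetyl in place of methyl on the sulfonamide nitrogen gives a small step (a number 0.9 percentage points lower from compound 3 to compound 4 (within the scatter)), so this larger group, which brings a carbonyl, did not move the read-out beyond the scatter any more than the earlier change at this place did. The longer comparisons read the same way, both for acetamido in place of methyl on the sulfonyl sulfur (a number 1.2 percentage points lower from compound 2 to compound 4 (within the scatter)) and for the whole group that compound 4 carries there (a number 2.1 percentage points lower from compound 1 to compound 4 (within the scatter)), so every group shown at this position leaves the four compounds inseparable at the concentration tested. Nothing measured here accounts for these readings.

As far as these compounds go, it remains open whether a different group would produce a step beyond the scatter, such as benzoyl or a longer acyl chain like butanoyl on the sulfonamide nitrogen, or a carboxylic acid or an amine on the aromatic carbon. From the compounds shown here alone, with a read-out at a single concentration, it also remains open whether these four compounds would separate at a lower concentration or in a measured potency.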